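The source may report more compounds than this note shows. Statements on the series, on what has been measured and on what is new or still open speak of the compounds shown alone.

Measured compounds, with the numbers seen in a functional assay on 143B cells (Homo sapiens) for inhibition, read by CCK-8 assay, with a stated time of 72 h, tested at 1 uM; on this read-out lower numbers stand for less inhibition and higher numbers for more inhibition at the one concentration tested (going by the name of the read-out):
- Compound 1 `COc1ccc(C)cc1N1C(=O)CSC1c1cccc(C(=O)NCCCCc2ccccc2)c1` gives 29%.
- Compound 2 `COc1cccc(OC)c1N1C(=O)CSC1c1cccc(C(=O)NCCCCc2ccccc2)c1` gives 31%.
- Compound 3 `O=C(NCCCCc1ccccc1)c1cccc(C2SCC(=O)N2c2ccccc2F)c1` gives 59%.

Compound 3 stands highest of the three in this assay; its nearest neighbour is compound 2, and the gap from compound 2 to compound 3 is a number 28 percentage points higher from compound 2 to compound 3 (beyond the scatter). Compound 1 lies furthest away, the gap being a number 30 percentage points higher from compound 1 to compound 3 (beyond the scatter). Compound 1 and compound 2 sit within the scatter of each other, as a number 2 percentage points higher from compound 1 to compound 2 (within the scatter) shows.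

Compound 4 `COc1c(F)cccc1N1C(=O)CSC1c1cccc(C(=O)NCCCCc2ccccc2)c1` differs from compound 3 in one place: 3-fluoro-2-methoxyphenyl in place of 2-fluorophenyl on an amide-type nitrogen in a ring. The two measured steps that bear on this are those from compound 1 and from compound 2 to compound 3, in which a methoxy-bearing aryl group on the ring nitrogen gave way to 2-fluorophenyl and the reading rose by a modest but clear amount. Compound 4 reintroduces a methoxy-bearing aryl group while keeping a fluorine, so the expectation is a step back toward the readings of compound 1 and compound 2, though not necessarily all the way, and possibly a step of no more than the scatter. The expected step is a number 17 percentage points lower from compound 3 to compound 4 (beyond the scatter). Compound 4 is therefore estimated to give 42% in this assay, within a range from 24% to 60%.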

Compound 4, a percentage reported as inhibition, at one concentration (the size of the read-out at that concentration, not a potency): 5%
Estimate against measurement, compound 4: 37 percentage points above; measured number below the stated range.
By their numbers in this assay, from the lowest: compound 4; then compounds 1 and 2 (each within the scatter of the next); then compound 3.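

In this assay the change from 2-fluorophenyl to 3-fluoro-2-methoxyphenyl on the amide-type nitrogen in the ring gives a number 54 percentage points lower from compound 3 to compound 4 (beyond the scatter) and so shows that keeping a fluorine on the aryl group does not keep the reading. The earlier methoxy-bearing groups did not set a lower bound at this position either: 3-fluoro-2-methoxyphenyl in place of 2,6-dimethoxyphenyl gives a number 26 percentage points lower from compound 2 to compound 4 (beyond the scatter) and in place of 2-methoxy-5-methylphenyl gives a number 24 percentage points lower from compound 1 to compound 4 (beyond the scatter) even though those two earlier groups had read within the scatter of each other, so methoxy-bearing aryl groups here do not all behave alike. Nothing available explains why the reading falls with this change.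

As far as these compounds go, it remains open whether the fall belongs to the methoxy group, to the fluorine in its new place or to the two together, a question that a 2-methoxyphenyl and a 3-fluorophenyl group would help to separate. The compounds shown also leave open how this position would respond to an aryl group carrying an amine or a carboxylic acid.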